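The source may hold more compounds than are shown below. What is called first, only, known or untested is meant among the compounds shown, and "the series" means these compounds.

In a functional assay on SF-295 cells (Homo sapiens) for inhibition, read by colorimetric assay and sulforhodamine B assay, with a stated time of 48 h (a lower number here means a stronger inhibitor of growth, a higher number a weaker inhibitor of growth), compound 1 `CCCCCCCCCCCC[C@@H](O)[C@H]1CC[C@H]([C@H](O)CCCCCCCCCCNC(=O)c2cccs2)O1` gives 1410 nM and compound 2 `CCCCCCCCCCCC[C@@H](O)[C@H]1CC[C@H]([C@H](O)CCCCCCCCCCNC(=O)c2cncs2)O1` gives 43700 nM while compound 3 `CCCCCCCCCCCC[C@@H](O)[C@H]1CC[C@H]([C@H](O)CCCCCCCCCCNC(=O)c2ccsc2)O1` gives 1000 nM on the same core. Compound 3 thus sits together with compound 1 at the low end of these numbers and far from compound 2. Compound 4 `CCCCCCCCCCCC[C@@H](O)[C@H]1CC[C@H]([C@H](O)CCCCCCCCCCNC(=O)c2ccnn2C)O1` has 1-methyl-1H-pyrazol-5-yl in place of thiophen-3-yl on a carbonyl carbon. Going by the values given here, the thiophen-2-yl and thiophen-3-yl amides are separated by a 1.4-fold lower number from compound 1 to compound 3 (0.15 log units; within the scatter) whereas the 1,3-thiazol-5-yl amide stands apart, with a 31-fold higher number from compound 1 to compound 2 (1.49 log units; beyond the scatter) and a 44-fold lower number from compound 2 to compound 3 (1.64 log units; beyond the scatter) as the steps that bear on this change. No measured ring matches the entering one, so a rise smaller than those large steps is expected in this assay and the expected step is a 6.0-fold higher number from compound 3 to compound 4 (0.78 log units; beyond the scatter) as a rough guide. Compound 4 is thus expected at 6000 nM (estimated range 1200 nM to 30000 nM).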

Compound 4, concentration for 50% growth inhibition: 10000 nM
For compound 4 the middle estimate is 1.7-fold (0.22 log units) below the measured one, and the stated range covers the measured number.
By their numbers in this assay, from the lowest: compounds 3 and 1 (each within the scatter of the next); then compound 4; then compound 2.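

In this assay, a second ring other than thiophene on this carbonyl carbon also raises the number, with a 10-fold higher number from compound 3 to compound 4 (1.00 log units; beyond the scatter) and a 7.1-fold higher number from compound 1 to compound 4 (0.85 log units; beyond the scatter), so compound 2 is no longer alone in standing apart from the two thiophene amides. These two rings do not share one level, however, with a 4.4-fold lower number from compound 2 to compound 4 (0.64 log units; beyond the scatter). Nothing available explains these differences. On these data alone, whether a plain phenyl ring would stay with the thiophene amides remains open, and so does the part played by the methyl group of the 1-methyl-1H-pyrazol-5-yl ring.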